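Methyl(methylsulfonyl)amino in place of acetamido on the shared core

This account rests on a few compounds, and the source may have more. Where it says the series, first, only, none or still open, it means among the compounds named here.

Compound 1 `CC(=O)Nc1cccc2c1CCCC2c1c[nH]cn1` stands only at a limit in an assay on isolated protein for binding affinity to Alpha-1D adrenergic receptor (Rattus norvegicus), read by radioligand binding; on this read-out higher numbers stand for weaker inhibition and lower numbers for stronger inhibition: its inhibition constant is given as < 10000 nM, a limit of the assay rather than a number (the limit of < 10000 nM in this assay, at which 1 of the 3 values shown sits). Compound 3 `CCS(=O)(=O)Nc1cc(F)cc2c1CCCC2c1c[nH]cn1`, which carries an ethylsulfonyl amino group and a fluorine on the same core, gives 3630 nM in this assay. Compound 2 `CCS(=O)(=O)Nc1cccc(NC2=NCCN2)c1`, on a different scaffold, gives 355 nM. Compound 4 `CN(c1cccc2c1CCCC2c1c[nH]cn1)S(C)(=O)=O` is not yet measured; it differs from compound 1 by methyl(methylsulfonyl)amino in place of acetamido on an aromatic carbon. Among the compounds with values here, no measured step covers this change. The nearest comparison is compound 3, whose value of 3630 nM sits in the weak range. The step that the limit leaves unreadable from compound 1 to compound 4 is expected to be modest and to leave compound 4 in that range. Compound 4 is estimated at 4000 nM, with a range of 800 nM to 20000 nM.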

Compound 4, inhibition constant: 708 nM
The estimate for compound 4 lay 5.6-fold (0.75 log units) above the measured number; measured number outside the range, below it.
By their numbers in this assay, from the lowest: compounds 2 and 4 (each within the scatter of the next); then compound 3.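

No step can be read from compound 1 to compound 4, as compound 1 stands only at a limit: the limit of < 10000 nM in this assay, at which 1 of the 4 values shown sits. The compounds shown leave open what size of change methyl(methylsulfonyl)amino in place of acetamido brings on the shared core.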